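Swapping a chlorothiophene for a benzyl group

This account rests on a few compounds, and the source may have more. Where it says the series, first, only, none or still open, it means among the compounds named here.

Measured so far:
Compound 1, `CCOC(=O)c1cnc(-c2cccc(OC)c2)nc1NN1C(=O)C=C(C)C1=O`: 5000 nM
Compound 2, `CCOC(=O)c1cnc(-c2ccc(Cl)s2)nc1NN1C(=O)C=C(C)C1=O`: 300 nM

In a functional assay on Jurkat cells for inhibition of nuclear factor NF-kappa-B complex (Homo sapiens) (a lower number here means a stronger inhibitor, a higher number a weaker inhibitor), compound 2 gives 300 nM, the lowest of the two numbers on hand. Among the measured compounds shown here, the only other measured compound, compound 1, gives 5000 nM in this assay. For the measured compounds named here, the single known step is a 17-fold lower number from compound 1 to compound 2 (1.22 log units; beyond the scatter), and it shows that the group on this aromatic carbon of the shared core can move the number a great deal.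

Compound 3, `CCOC(=O)c1cnc(Cc2ccccc2)nc1NN1C(=O)C=C(C)C1=O`, has not been measured. It differs from compound 2 by benzyl in place of 5-chlorothiophen-2-yl on an aromatic carbon. The measured step compares two aromatic rings attached directly to the core; here the ring is instead carried on a methylene, and the sulfur and chlorine are gone. Going by the values given here, no measured pair shows this kind of change, so the direction is uncertain, but the known step suggests a sizeable shift is plausible, and departing from the best group so far more often costs potency than gains it. Compound 3 is therefore expected to give 3000 nM, between 700 nM and 13000 nM. This estimate corresponds to a 10-fold higher number from compound 2 to compound 3 (1.00 log units; beyond the scatter).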

Compound 3, half-maximal inhibitory concentration: 7000 nM
For compound 3 the middle estimate is 2.3-fold (0.37 log units) below the measured one; the measured number falls inside the stated range.
By their numbers in this assay, from the lowest: compound 2; then compounds 1 and 3 (each within the scatter of the next).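

In this assay the change from 5-chlorothiophen-2-yl to benzyl gives a 23-fold higher number from compound 2 to compound 3 (1.37 log units; beyond the scatter) and so undoes the gain seen earlier, which shows that this place on the shared core responds strongly to a second kind of group as well. The comparison of benzyl with 3-methoxyphenyl gives a 1.4-fold higher number from compound 1 to compound 3 (0.15 log units; within the scatter) and does not separate these two groups, even though the ring of benzyl is carried on a methylene and the ring of 3-methoxyphenyl is attached directly to the core, so among these three compounds only the 5-chlorothiophen-2-yl group stands apart. No information is available to explain why this one group differs from the other two.

These compounds cannot show whether the chlorine, the sulfur-containing ring, or the two together account for the lower number of compound 2, since the chlorine and the sulfur leave together in every comparison. A thiophen-2-yl group without chlorine and a chlorophenyl group would pull these two parts apart, while an amine at this place would test whether a ring is needed there at all.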